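The source may hold more compounds than are shown below. What is called first, only, known or untested is meant among the compounds shown, and "the series" means these compounds.

Compound 1 `CCOC(=O)CN(c1ccccc1)[C@H]1c2cc(C#N)ccc2OC(C)(C)[C@@H]1O` is tested in a functional assay (aorta) with Rattus norvegicus as the target; a lower number here means a stronger inhibitor, a higher number a weaker inhibitor. In this assay compound 1 gives only a limit, > 30000 nM, so its standing is known just as a range rather than a number (the limit of > 30000 nM in this assay, at which 1 of the 2 values shown sits). Compound 2 `CC1(C)Oc2ccc(C#N)cc2[C@H](N(CC#N)c2ccccc2)[C@H]1O` differs by a cyano in place of ethoxycarbonyl on a saturated chain carbon bound to a nitrogen on an aromatic ring; in this assay compound 2 gives 59000 nM. The step that the limit leaves unreadable from compound 1 to compound 2 cannot be sized, since the limit on one side hides it. Compound 3 `CC1(C)Oc2ccc(C#N)cc2[C@H](N(Cc2ncco2)c2ccccc2)[C@H]1O` is not yet measured and differs from compound 1 by 1,3-oxazol-2-yl in place of ethoxycarbonyl on a saturated chain carbon bound to a nitrogen on an aromatic ring. Going by the values given here, the only measured step touching this position has no readable size, so no direction beyond the scatter can be foreseen. Compound 3 is expected to stay in the same weak region, with an estimated step that the limit leaves unreadable from compound 1 to compound 3. The estimate for compound 3 is 40000 nM, expected to fall between 12000 nM and 130000 nM.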

Compound 3, half-maximal inhibitory concentration: > 30000 nM
Compound 3 gave a limit, no number (the forecaster's own chance of this, stated with the estimate: 50%); the middle value lies beyond the limit too.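

No step can be read from compound 1 or compound 2 to compound 3, because compound 3 gives only a limit in this assay: the limit of > 30000 nM in this assay, at which 2 of the 3 values shown sit.

The compounds shown leave open whether any of these three groups gives a stronger inhibitor than the others.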